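Cyano for chloro on the anilide of compound 2

The source may hold more compounds than are shown below. What is called first, only, known or untested is meant among the compounds shown, and "the series" means these compounds.

Measured so far:
compound 1 `CN1CC2(C1)CN(c1ccc(OCc3ccccc3)c(C(=O)Nc3ccnnc3)c1)C2`: 25.1 nM
compound 2 `O=C(Nc1cccc(Cl)c1)c1cc(C(F)(F)F)ccc1OCc1ccc(F)cc1`: 12.6 nM

In an assay on Sf9 cells for inhibition of Leucine-rich repeat serine/threonine-protein kinase 2 (Homo sapiens), read by TR-FRET, with stated times of 30 min and 2 h (on this read-out lower numbers stand for stronger inhibition and higher numbers for weaker inhibition), compound 2 gives the lowest of the two numbers, yet compound 1 stands within the scatter of it, so no order between the two can be read. Compound 3 `N#Cc1cccc(NC(=O)c2cc(C(F)(F)F)ccc2OCc2ccc(F)cc2)c1` is not yet measured. It differs from compound 2 by cyano in place of chloro on an aromatic carbon. Within the data shown here, no step between measured compounds is known for this series, so the change is expected to move the number by no more than the scatter, in either direction. Compound 3 is therefore estimated at 18 nM, range 6 nM to 55 nM, which means an expected step of a 1.4-fold higher number from compound 2 to compound 3 (0.15 log units; within the scatter).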

Compound 3, half-maximal inhibitory concentration: 7.94 nM
Estimate against measurement, compound 3: 2.3-fold (0.36 log units) above, and the stated range covers the measured number.
By their numbers in this assay, from the lowest: compounds 3, 2 and 1 (each within the scatter of the next, the first and the last beyond it).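

In this assay, among these compounds, the exchange of 3-chlorophenyl for 3-cyanophenyl gives a 1.6-fold lower number from compound 2 to compound 3 (0.20 log units; within the scatter) and this is the first comparison that differs in one place. At this position on the anilide, cyano can therefore stand in place of chloro with no order readable between compound 2 and compound 3. No measurement given here bears on a cause for this result.

Going by these compounds, whether the same exchange reads alike on the core of compound 1 remains open. Also open, on these data alone, is how an amine, a carboxylic acid or a methoxy group would read at this position.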